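From Methyl to Chloro: Estimating Compound 3

The source may report more compounds than this note shows. Statements on the series, on what has been measured and on what is new or still open speak of the compounds shown alone.

Measured in a functional assay on KM12 cells (Homo sapiens) for antiproliferative activity; on this read-out lower numbers stand for stronger inhibition of growth and higher numbers for weaker inhibition of growth:
- compound 1 `COc1ccc(-c2nc3ccccc3s2)cc1OC`: 74200 nM
- compound 2 `COc1ccc(-c2nc3cc(F)ccc3s2)cc1C`: 18600 nM

Of these two, compound 2 has the lower number, so it inhibits growth more strongly, and the gap lies beyond the usual scatter. Compound 3 `COc1ccc(-c2nc3cc(F)ccc3s2)cc1Cl` has chloro in place of methyl on an aromatic carbon, ortho to a methoxy group (chloro in place of methyl on an aromatic carbon). Within the data shown here, no measured pair shows this swap, so the expectation in this assay is for no change beyond the scatter. The estimated change is a 1.6-fold lower number from compound 2 to compound 3 (0.19 log units; within the scatter). Compound 3 is expected to give about 12000 nM, within an estimated range of 2500 nM to 50000 nM.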

Compound 3, concentration for 50% growth inhibition: 7050 nM
Beside the measured number, compound 3's estimate is 1.7-fold (0.23 log units) above it, and the stated range covers the measured number.
By their numbers in this assay, from the lowest: compound 3; then compound 2; then compound 1.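

In this assay, putting chloro in place of methyl on this aromatic carbon, ortho to a methoxy group, gives a 2.6-fold lower number from compound 2 to compound 3 (0.42 log units; beyond the scatter). Among these compounds, this is the first pair here that differs in one place, and it shows that growth inhibition responds to this single swap, though only modestly. Nothing measured here explains the shift. Still open, on these data alone, is how a nitrile, an amine or a longer chain would fare at this position. The compounds shown also leave open whether the same swap would give a similar step on a different core.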